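Methoxy to ethyl on compound 2

The source may report more compounds than this note shows. Statements on the series, on what has been measured and on what is new or still open speak of the compounds shown alone.

Values in a functional assay on MCF7 cells (Homo sapiens) for antiproliferative activity, with a stated time of 5 days; a higher number here means a weaker inhibitor, a lower number a stronger inhibitor
- compound 1 `CCCCc1ccc2[nH]c(-c3ccc(OC)cc3)c(/C=N/O)c2c1` gives 212 nM
- compound 2 `CCCCc1ccc2[nH]c(-c3ccc(OC)cc3)c(/C=N/NC(=O)c3cccnc3)c2c1` gives 75 nM

For the measured compounds named here, of these two compounds, compound 2 has the lower number, at 75 nM against the higher value of its only neighbour. Compound 3 `CCCCc1ccc2[nH]c(-c3ccc(CC)cc3)c(/C=N/NC(=O)c3cccnc3)c2c1` has ethyl in place of methoxy on an aromatic carbon, para to a large group (ethyl in place of methoxy on an aromatic carbon), so that 4-methoxyphenyl becomes 4-ethylphenyl. Going by the values given here, the only measured step (a 2.8-fold lower number from compound 1 to compound 2 (0.45 log units; beyond the scatter)) is modest and beyond the scatter, but it exchanges hydroxy for ((pyridin-3-yl)carbonyl)amino on a double-bonded nitrogen and leaves the methoxy untouched. Among the compounds with values here, it therefore gives no size or direction for the present change, and no measured pair varies this group. No step beyond the scatter is expected in this assay, and neither direction is favoured. The estimate is anchored on compound 2 at 75 nM and carries a wide range. The estimated change is a 1.2-fold higher number from compound 2 to compound 3 (0.08 log units; within the scatter) and remains an expectation only. For compound 3 the expected value is 90 nM with an estimated range from 30 nM to 260 nM in this read-out.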

Compound 3, half-maximal inhibitory concentration: 100 nM
For compound 3 the middle estimate is 1.1-fold (0.05 log units) below the measured one, within the range that was stated.
By their numbers in this assay, from the lowest: compounds 2 and 3 (each within the scatter of the next); then compound 1.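

In this assay, for the compounds shown here, the exchange of 4-methoxyphenyl for 4-ethylphenyl gives a 1.3-fold higher number from compound 2 to compound 3 (0.12 log units; within the scatter) and provides the first reading at this position on the aromatic carbon, para to a large group. In this pair, the two groups are not separated, although the exchange replaces an oxygen with a carbon and takes the group's hydrogen-bond acceptor count from one to zero, so that acceptor is not needed for compound 3 to stay within the scatter of compound 2. The data in hand offer no explanation for this outcome.

With only methoxy and ethyl shown here, the response of this position to an amine, a carboxylic acid or a longer chain remains open, so the pair sets no limit on what the position accepts. On these data alone, it is also open whether the same exchange would read the same way with the hydroxy on the double-bonded nitrogen of compound 1, since the exchange appears here only with the ((pyridin-3-yl)carbonyl)amino group in place.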